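The source may report more compounds than this note shows. Statements on the series, on what has been measured and on what is new or still open speak of the compounds shown alone.

Compound 1 `Cc1ccc(-c2nc(Nc3ccc(C(=O)Nc4c(C)cccc4C)cc3)ncc2C)cc1`; compound 2 `Cc1cnc(Nc2ccc(C(=O)Nc3c(C)cccc3C)cc2)nc1-c1cnn(C)c1`.

In an assay on NIH3T3 cells for inhibition of Sonic hedgehog protein (Mus musculus), read by a luciferase reporter, with a stated time of 48 h (on this read-out higher numbers stand for weaker inhibition and lower numbers for stronger inhibition), compound 1 gives only a limit of the assay, > 500 nM. In this assay, among the measured compounds shown here, compound 2 gives 10.6 nM, the only plain number among the two measured values. The other value shown, that of compound 1, is a limit, namely (the limit of > 500 nM in this assay, at which 1 of the 2 values shown sits). Compound 3 `Cc1cnc(Nc2ccc(C(=O)Nc3c(C)cccc3C)cc2)nc1Cc1ccccc1` is not yet measured; it differs from compound 2 by benzyl in place of 1-methyl-1H-pyrazol-4-yl on an aromatic carbon. For the measured compounds named here, one measured step bears on this change: an at least 47-fold lower number from compound 1 to compound 2 (1.67 log units; beyond the scatter), a large gain when the 1-methyl-1H-pyrazol-4-yl group entered in place of a six-membered ring of carbon only. In compound 3 that same group leaves again and benzyl, another six-membered aromatic ring of carbon only, enters, so the number is expected to move back up, toward weaker inhibition. Compound 3 is therefore expected to give about 300 nM, within 60 nM to 1500 nM, a step of a 28-fold higher number from compound 2 to compound 3 (1.45 log units; beyond the scatter). It is also expected that the assay may again report only a limit for compound 3.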

Compound 3, half-maximal inhibitory concentration: 34.3 nM
Beside the measured number, compound 3's estimate is 8.7-fold (0.94 log units) above it; the whole stated range lies above it.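

The ring nitrogens of the 1-methyl-1H-pyrazol-4-yl group are not essential for strong inhibition at this position: in this assay, benzyl, a ring of carbon only with no hydrogen-bond acceptors, brings only a modest loss, a 3.2-fold higher number from compound 2 to compound 3 (0.51 log units; beyond the scatter). A ring of carbon only therefore does not in itself weaken inhibition here, and the choice of carbon-only group matters, with benzyl in place of 4-methylphenyl giving an at least 14-fold lower number from compound 1 to compound 3 (1.16 log units; beyond the scatter). As far as these compounds go, the true size of that gain stays unknown because compound 1 has a limit and not a plain number: the limit of > 500 nM in this assay, at which 1 of the 3 values shown sits.

Benzyl and 4-methylphenyl differ both in the linking carbon of benzyl and in the methyl group on the ring of 4-methylphenyl, and the compounds shown do not separate these two features. A plain phenyl group would bear on that question, and a 2-phenylethyl group would show whether a longer link is tolerated.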